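The source may report more compounds than this note shows. Statements on the series, on what has been measured and on what is new or still open speak of the compounds shown alone.

Measured in a functional assay on MCF7 cells (Homo sapiens) for inhibition, read by MTT assay, with a stated time of 72 h; a higher number here means a weaker inhibitor, a lower number a stronger inhibitor:
- compound 1 `COc1cccc(/C=C/C(=O)Nc2cc(OC)c(OC)c(OC)c2)c1`: 27000 nM
- compound 2 `C=C(Br)C(=O)Nc1cccc(/C=C/C(=O)Nc2ccc(OC)cc2)c1`: 2500 nM
- compound 3 `C=C(Br)C(=O)Nc1ccc(/C=C/C(=O)Nc2ccc(OC)cc2)cc1`: 3000 nM

Compound 1 has the highest number of the three in this assay, so it is the weakest inhibitor measured so far. Its gaps to both other compounds lie beyond the scatter. Compound 2 and compound 3 lie within the scatter of each other.

Next is compound 4 `COc1cc(NC(=O)/C=C/c2cccc(N)c2)cc(OC)c1OC`, which carries amino in place of methoxy on an aromatic carbon, meta to a large group: amino in place of methoxy on an aromatic carbon. In other words, 3-methoxyphenyl becomes 3-aminophenyl, and the rest of the structure stays as in compound 1.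

Among the measured compounds shown here, no measured pair isolates this change. Compound 2 and compound 3 differ from compound 1 in more than one place, so they do not show the size of this step. For the measured compounds named here, the expectation therefore rests mainly on compound 1 at 27000 nM, the only measured compound that shares the rest of compound 4. No step beyond the scatter is expected in this assay, in either direction, though the uncertainty is wide. The estimated change is a 1.4-fold lower number from compound 1 to compound 4 (0.13 log units; within the scatter).

For compound 4 the expected value is 20000 nM, with an estimated range of 7000 nM to 60000 nM.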

Compound 4, half-maximal inhibitory concentration: 55400 nM
The estimate for compound 4 lay 2.8-fold (0.44 log units) below the measured number, and the stated range covers the measured number.
By their numbers in this assay, from the lowest: compounds 2 and 3 (each within the scatter of the next); then compound 1; then compound 4.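

In this assay, among the compounds shown here, this is the first step read at a single place on the core of compound 1: amino in place of methoxy on an aromatic carbon, meta to a large group, gives a 2.1-fold higher number from compound 1 to compound 4 (0.31 log units; beyond the scatter) with the rest of the structure unchanged. The step is modest but lies beyond the scatter, so this place is not indifferent to the exchange of 3-methoxyphenyl for 3-aminophenyl, and here the exchange moves the series towards weaker inhibition, which compound 2 and compound 3, each differing from compound 1 in more than one place, could not show. Nothing at hand accounts for the step, which stands as an observation only.

One step at one place leaves open whether the trend belongs to amino alone or extends to other groups there, such as hydroxyl, acetamido or dimethylamino. On these data alone, it also remains open how the step would read on a core carrying the 4-methoxyphenyl amide of compound 2 and compound 3, and whether a bromoacrylamide built on the amino group of compound 4 would follow those two compounds.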